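Swapping chloromethyl for furan-2-yl at an assay limit

The source may report more compounds than this note shows. Statements on the series, on what has been measured and on what is new or still open speak of the compounds shown alone.

Results in an ADME assay on L02 cells (Homo sapiens) for cytotoxicity, read by MTT assay (a higher number here means a weaker inhibitor, a lower number a stronger inhibitor), for three compounds:
- compound 1 `COc1ccc(/C=C/C(=O)c2ccc(OC)c3c2OC(C)(C)C=C3)cc1O` gives > 10000 nM as a limit
- compound 2 `CCCCC(=O)Oc1cc(/C=C/C(=O)c2ccc(OC)c3c2OC(C)(C)C=C3)ccc1OC` gives > 10000 nM as a limit
- compound 3 `COc1ccc(/C=C/C(=O)c2ccc(OC)c3c2OC(C)(C)C=C3)cc1OC(=O)CCl` gives > 10000 nM as a limit

Compound 3 has no exact number of its own: the set offers only the limit of > 10000 nM in this assay, at which 3 of the 3 values shown sit, and so the three compounds cannot be ranked.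

Compound 4 `COc1ccc(/C=C/C(=O)c2ccc(OC)c3c2OC(C)(C)C=C3)cc1OC(=O)c1ccco1` differs from compound 3 in one group on the carbonyl carbon: furan-2-yl in place of chloromethyl on a carbonyl carbon and in words this is furan-2-yl in place of chloromethyl.

The measured steps that bear on this change are a step that the two limits leave unreadable from compound 2 to compound 3 and a step that the two limits leave unreadable from compound 1 to compound 3 and also a step that the two limits leave unreadable from compound 1 to compound 2 and none of them has a readable size. All three changes at this oxygen left the reading at the limit, so they suggest no direction. The expected outcome is a number no higher from compound 3 to compound 4 (the limit leaves the size open) and no shift beyond the usual scatter is foreseen. For compound 4 the estimate is 10000 nM with an expected range from 4000 nM to 20000 nM and a report as a limit is the likeliest result.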

Compound 4, half-maximal inhibitory concentration: > 10000 nM
Compound 4: a limit, no number; the forecaster's own chance of this, stated with the estimate: 80%; the middle value sits exactly at the limit.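

Compound 4 also gives a limit rather than a number, so no step from compound 1, compound 2 or compound 3 to compound 4 can be read: the limit of > 10000 nM in this assay, at which 4 of the 4 values shown sit.

The compounds shown leave open how they rank in this assay, and whether any change at this oxygen alters the reading.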